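Ethylamino for Benzylsulfanyl on a Nucleoside Core

This account rests on a few compounds, and the source may have more. Where it says the series, first, only, none or still open, it means among the compounds named here.

Measured so far:
compound 1 `OC[C@H]1OC(n2cnc3c(SCc4ccccc4)nccc32)[C@H](O)[C@@H]1O`: 30%
compound 2 `CCCCCCNc1[nH]ccc2ncnc1-2`: 53%

Of the compounds shown here, two have been measured in a functional assay (Homo sapiens) for inhibition of Nucleic Acid, tested at 100 uM; on this read-out lower numbers stand for less inhibition and higher numbers for more inhibition at the one concentration tested (going by the name of the read-out). Compound 1 gives 30% in this assay, the lower of the two numbers. Compound 2, which carries a hexylamino group on a core without the sugar, gives 53% in this assay, a number that lies beyond the scatter above that of compound 1. The two differ in more than one place, so no single step can be read from them; the values only show that the hexylamino compound inhibits more.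

Compound 3 `CCNc1nccc2c1ncn2C1O[C@H](CO)[C@@H](O)[C@H]1O` keeps the sugar and the core of compound 1. Its change is ethylamino in place of benzylsulfanyl on an aromatic carbon. The benzylsulfanyl group, with its one six-membered aromatic ring of carbon only, leaves; ethylamino, with no ring and one hydrogen-bond donor, enters at the same aromatic carbon next to the ring nitrogen.

With compound 2 as the only pointer towards an alkylamino at this place, a modest rise is expected, though one that may not clear the scatter: a number 10 percentage points higher from compound 1 to compound 3 (within the scatter) is the expected step. Compound 3 is therefore estimated at 40% in this assay, within a range from 15% to 65%.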

Compound 3, a percentage reported as inhibition, at one concentration (the size of the read-out at that concentration, not a potency): 4%
Compound 3: the middle estimate sits 36 percentage points above what was measured, outside the stated range (below it).
By their numbers in this assay, from the lowest: compound 3; then compound 1; then compound 2.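

Ethylamino in place of benzylsulfanyl on an aromatic carbon next to the ring nitrogen gives a number 26 percentage points lower from compound 1 to compound 3 (beyond the scatter) in this assay, the first reading of a single change at this position. It shows that the position is not indifferent to what it carries, and that an alkylamino group on the sugar-bearing core does not by itself raise the number. The change removes the six-membered aromatic ring and the sulfur and goes from 8 heavy atoms to 3 while adding a hydrogen-bond donor, so this one step cannot separate these differences. Nothing at hand accounts for the size or direction of the step and it stands as an observation only.

From the compounds shown here alone, it remains open whether a hexylamino group on the sugar-bearing core would give a higher number than ethylamino, which would show whether chain length matters at this place. A benzylamino group or a hexylsulfanyl group here would also help to tell whether the ring or the sulfur counts for more.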